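The source may report more compounds than this note shows. Statements on the series, on what has been measured and on what is new or still open speak of the compounds shown alone.

Compound 1 `Cc1ccc(C2=NN(c3nc(-c4ccccc4)cs3)C(c3ccc(F)cc3)C2)s1`: > 500 ug/mL
Compound 2 `CS(=O)(=O)c1ccc(-c2csc(N3N=C(c4ccc(Cl)s4)CC3c3ccc(F)cc3)n2)cc1`: > 500 ug/mL
Compound 3 `Fc1ccc(C2CC(c3ccc(Cl)s3)=NN2c2nc(-c3ccccc3)cs2)cc1`: > 500 ug/mL

In a functional assay on A549 cells (Homo sapiens) for antiproliferative activity, read by XTT assay, with a stated time of 24 h (on this read-out lower numbers stand for stronger inhibition and higher numbers for weaker inhibition), compound 1 gives > 500 ug/mL, which is a limit of the assay and not a number. Compound 2 likewise stops at a limit, > 500 ug/mL. Compound 3 also reaches only a limit, > 500 ug/mL. All three values therefore rest at the same ceiling, (the limit of > 500 ug/mL in this assay, at which 3 of the 3 values shown sit), and compound 1 cannot be placed relative to its two neighbours on these numbers.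

Compound 4 `COc1ccc(-c2csc(N3N=C(c4ccc(C)s4)CC3c3ccc(F)cc3)n2)cc1` differs from compound 1 by methoxy in place of hydrogen on an aromatic carbon. Two measured steps run through this shared core, a step that the two limits leave unreadable from compound 1 to compound 3 and a step that the two limits leave unreadable from compound 2 to compound 3, and neither has a readable size because both of their ends sit at the limit (the limit of > 500 ug/mL in this assay, at which 3 of the 3 values shown sit). Nothing measured here sets a direction for the new group.

Given that compound 1 stands at > 500 ug/mL and every measured relative shares that limit, compound 4 is expected to show no step beyond the scatter, a number no higher from compound 1 to compound 4 (the limit leaves the size open). Compound 4 is therefore estimated at 500 ug/mL, with a range from 150 ug/mL to 1500 ug/mL, and is most likely to be reported again only as a limit.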

Compound 4, half-maximal inhibitory concentration: 184 ug/mL
The estimate for compound 4 lay 2.7-fold (0.43 log units) above the measured number; low and high end bracket the measured number.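

In this assay, among these compounds, the change from phenyl to 4-methoxyphenyl gives the only readable step so far, an at least 2.7-fold lower number from compound 1 to compound 4 (0.43 log units; beyond the scatter). Among the compounds shown here, this shows that on this aromatic carbon, para to a large group, methoxy in place of hydrogen can bring the number down from the ceiling, and it gives the change a direction that the earlier compounds could not. The earlier steps cannot be read, because both ends of each rest at the limit: the limit of > 500 ug/mL in this assay, at which 3 of the 4 values shown sit.

The compounds shown leave open whether methoxy would have the same effect on compound 3, and how a hydroxy group, an amine or a carboxylic acid would read on this carbon. On these data alone, the full size of the step also stays open, as the value of compound 1 is only a limit.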